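The compounds below may be only part of what the source reports. "The series", "measured", "known", "first", "only" and "open" are said of these compounds alone.

Measured in a functional assay on HepG2 cells (Homo sapiens) for cytotoxicity, with a stated time of 72 h; a lower number here means that less compound is needed, a higher number that more compound is needed for the effect:

- Compound 1 `C=C[C@@](C)(/C=C/c1ccc(OS(=O)(=O)C(F)(F)F)cc1)CCC=C(C)C`: > 52000 nM (a limit)
- Compound 2 `C=C[C@@](C)(/C=C/c1ccc(Nc2c(F)cc(F)cc2F)cc1)CCC=C(C)C`: > 52000 nM (a limit)
- Compound 3 `C=C[C@@](C)(/C=C/c1ccc(Nc2ccc(Cl)cc2)cc1)CCC=C(C)C`: > 52000 nM (a limit)

None of these entries is an exact number. Compound 3 therefore has no exact place in the series, and the whole set sits at the limit of > 52000 nM in this assay, at which 3 of the 3 values shown sit.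

The next compound is compound 4 `C=C[C@@](C)(/C=C/c1ccc(Nc2ccc(Cl)c(Cl)c2)cc1)CCC=C(C)C`. It differs from compound 3 by a single substitution: chloro in place of hydrogen on an aromatic carbon. Chloro takes the place of hydrogen on an aromatic carbon, so 4-chlorophenyl becomes 3,4-dichlorophenyl.

For the measured compounds named here, two measured steps bear on this change: a step that the two limits leave unreadable from compound 1 to compound 3, and a step that the two limits leave unreadable from compound 2 to compound 3. Neither has a readable size, so neither offers a direction to carry over. No step beyond the usual scatter is expected, and this expectation rests on compound 3 with its limit of > 52000 nM. Another limit is the most likely report for compound 4. Estimated in this way, the step is a step that the limit leaves unreadable from compound 3 to compound 4. For compound 4 the estimated value is 60000 nM, with an expected range from 25000 nM to 120000 nM.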

Compound 4, half-maximal effective concentration: > 52000 nM
Compound 4: only a limit was reported; the forecaster's own chance of this, stated with the estimate: 80%; the middle value lies beyond the limit too.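

In this assay compound 4 gives > 52000 nM as a limit, not an exact number. For the compounds shown here, no step among compound 1, compound 2, compound 3 and compound 4 can be read, because all their values are limits: the limit of > 52000 nM in this assay, at which 4 of the 4 values shown sit. On these data alone, how far each compound lies beyond this limit, and whether the added chloro changes the result, stays open.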